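From 3-Methylbenzyl to 4-Methoxybenzyl on a Shared Core

A few compounds are considered here, and "the series" means these few. Any claim that something is new, unique, unknown or untested is made for them only; others in the source may bear on it.

Compound 1 (`Cc1ccc(CN2CCc3ncn(COCc4ccccc4)c3/C(=C/c3ccccc3)C2=O)cc1`), compound 2 (`Cc1cc(C)cc(CN2CCc3ncn(COCc4ccccc4)c3/C(=C/c3ccccc3)C2=O)c1`) and compound 3 (`Cc1cccc(CN2CCc3ncn(COCc4ccccc4)c3/C(=C/c3ccccc3)C2=O)c1`) share one core and differ only in the methyl-bearing phenyl group on a saturated chain carbon bound to an amide-type nitrogen in a ring. In a functional assay on BGC-823 cells (Homo sapiens) for inhibition, read by MTT assay, with a stated time of 72 h (a lower number here means a stronger inhibitor, a higher number a weaker inhibitor), compound 1 gives 39100 nM, compound 2 gives 52600 nM and compound 3 gives 14600 nM. Compound 3 has the lowest number of the three and is the strongest inhibitor among them.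

Compound 4 (`COc1ccc(CN2CCc3ncn(COCc4ccccc4)c3/C(=C/c3ccccc3)C2=O)cc1`) differs from compound 3 at that same place: 4-methoxyphenyl in place of 3-methylphenyl on a saturated chain carbon bound to an amide-type nitrogen in a ring. Thus 4-methoxyphenyl stands in place of 3-methylphenyl. The most relevant measurement is a 2.7-fold lower number from compound 1 to compound 3 (0.43 log units; beyond the scatter), with 3-methylphenyl in place of 4-methylphenyl. The replacement of methyl by hydrogen on an aromatic carbon gave a 3.6-fold lower number from compound 2 to compound 3 (0.56 log units; beyond the scatter), while the remaining comparison shows a 1.3-fold higher number from compound 1 to compound 2 (0.13 log units; within the scatter). Within the data shown here, no measured compound carries a methoxy group, so that part of the change is untested. Compound 4 resembles compound 1 in bearing a 4-substituted name, so a modest rise in this assay is expected, an estimated 2.3-fold higher number from compound 3 to compound 4 (0.35 log units; beyond the scatter). For compound 4 the estimated value is 33000 nM, with an expected range of 13000 nM to 80000 nM.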

Compound 4, half-maximal inhibitory concentration: 71600 nM
For compound 4 the middle estimate is 2.2-fold (0.34 log units) below the measured one; measured number inside the range.
By their numbers in this assay, from the lowest: compound 3; then compounds 1, 2 and 4 (each within the scatter of the next).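

With its methoxy group, compound 4 brings the first oxygen atom and the first hydrogen-bond acceptor to this place on the shared core, and in this assay the change to 4-methoxyphenyl gives a 4.9-fold higher number from compound 3 to compound 4 (0.69 log units; beyond the scatter), the largest step yet seen at this position, so compound 3 remains the strongest inhibitor of the four. Methoxy in place of methyl gives a 1.8-fold higher number from compound 1 to compound 4 (0.26 log units; within the scatter), and 4-methoxyphenyl in place of 3,5-dimethylphenyl gives a 1.4-fold higher number from compound 2 to compound 4 (0.13 log units; within the scatter); both steps lie within the scatter, so this assay does not tell these groups apart. Of the four groups now compared, only 3-methylphenyl stands apart from the rest, which shows that the oxygen-bearing group does not restore the lower number and that the 4-substituted groups in compound 1 and compound 4 cannot be separated.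

The compounds shown leave open whether 3-methoxyphenyl would match the 3-methylphenyl of compound 3, and how a plain phenyl group, or a phenyl group carrying an amine or a carboxylic acid, would stand here. Nothing available explains why these groups give the numbers they do.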